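Solubility notes: from compound 3 to compound 4

The source may report more compounds than this note shows. Statements on the series, on what has been measured and on what is new or still open speak of the compounds shown alone.

Measured compounds:
compound 1, `CNC(=O)c1cc(Oc2ccc3nc(Nc4ccccc4)ncc3c2)ccn1`; in a physicochemical assay for solubility, at pH 7 (a higher number here means a more soluble compound, a lower number a less soluble compound), compound 1 gives < 1000 nM, which is a limit of the assay.
compound 2, `CNC(=O)c1cc(Oc2ccc3nc(Nc4ccccc4Br)ncc3c2)ccn1`; in this assay compound 2 gives < 1000 nM, again a limit.
compound 3, `CNC(=O)c1cc(Oc2ccc3nc(Nc4ccc(F)cc4)ncc3c2)ccn1`; in this assay compound 3 gives < 1000 nM, a limit as well.

All three values sit at the limit of < 1000 nM in this assay, at which 3 of the 3 values shown sit. In consequence none of the steps among the measured compounds can be read: a step that the two limits leave unreadable from compound 1 to compound 2, a step that the two limits leave unreadable from compound 1 to compound 3 and a step that the two limits leave unreadable from compound 2 to compound 3 are all unreadable in size and direction. Compound 3 therefore stands only at a limit in this assay, with nothing to rank it against compound 1 or compound 2.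

Compound 4, `CNC(=O)c1cc(Oc2ccc3nc(Nc4ccc(C(F)(F)F)cc4)ncc3c2)ccn1`, differs from compound 3 by trifluoromethyl in place of fluoro on an aromatic carbon. The measured steps that bear on this change, those from compound 1 to compound 2 and from compound 1 to compound 3, bring in a halogen on the same ring but yield no readable size, so no step beyond the scatter can be expected in either direction from them. The step that the limit leaves unreadable from compound 3 to compound 4 is accordingly an expectation that compound 4 stays at or under the limit. Compound 4 is estimated at 300 nM in this assay, within 50 nM to 1000 nM, most likely reported once more as a limit.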

Compound 4, solubility: < 1000 nM
Compound 4: no number, only a limit (the forecaster's own chance of this, stated with the estimate: 90%); the middle value lies beyond the limit too.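

In this assay compound 4 gives < 1000 nM, which is a limit of the assay. The steps to compound 4 from compound 1, compound 2 and compound 3 therefore cannot be read in size or direction: the limit of < 1000 nM in this assay, at which 4 of the 4 values shown sit. The compounds shown leave open where the solubility of each lies and whether any substituent change among them shifts it.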